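The source may report more compounds than this note shows. Statements on the series, on what has been measured and on what is new or still open speak of the compounds shown alone.

Three compounds share one core, a sulfonamide-linked bicyclic system carrying an aryl group on an aromatic carbon, and differ only in that aryl group. Compound 1 `COc1ccc(S(=O)(=O)N2CCc3cccc(-c4ccc([N+](=O)[O-])cc4)c32)cc1` gives 51.8 nM in a functional assay on HT-29 cells (Homo sapiens) for inhibition, with a stated time of 72 h; a lower number here means a stronger inhibitor, a higher number a weaker inhibitor. Compound 2 `COc1ccc(S(=O)(=O)N2CCc3cccc(-c4ccc(C#N)cc4)c32)cc1` gives 24.2 nM in this assay, and compound 3 `COc1ccc(S(=O)(=O)N2CCc3cccc(-c4ccc(F)c(F)c4)c32)cc1` gives 57 nM in this assay. Compound 3 thus shows the highest of the three numbers, yet a 1.1-fold higher number from compound 1 to compound 3 (0.04 log units; within the scatter) stays within the scatter, so only compound 2 is clearly separated from it: a 2.4-fold higher number from compound 2 to compound 3 (0.37 log units; beyond the scatter), while a 2.1-fold lower number from compound 1 to compound 2 (0.33 log units; beyond the scatter).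

Compound 4 `COc1ccc(-c2cccc3c2N(S(=O)(=O)c2ccc(OC)cc2)CC3)cc1` is not yet measured. From compound 3 the change is 4-methoxyphenyl in place of 3,4-difluorophenyl on an aromatic carbon. Both measured steps at this aryl position, from compound 1 to compound 3 and from compound 2 to compound 3, bear on this change, and neither exceeded a modest size; the aryl swaps shown moved the number at most by the step from compound 2 to compound 3. The two compounds whose aryl group carries a hydrogen-bond acceptor, compound 1 and compound 2, gave the lower numbers, and compound 4 brings one acceptor back. A modest improvement, a 1.4-fold lower number from compound 3 to compound 4 (0.15 log units; within the scatter), is therefore expected, and the number for compound 4 in this assay is estimated at 40 nM, within a range of 18 nM to 90 nM.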

Compound 4, half-maximal inhibitory concentration: 277 nM
Beside the measured number, compound 4's estimate is 6.9-fold (0.84 log units) below it, and the stated range ends below it.
By their numbers in this assay, from the lowest: compound 2; then compounds 1 and 3 (each within the scatter of the next); then compound 4.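

For the compounds shown here, at this aryl position, the swap to 4-methoxyphenyl is the first change to carry the number well away from the other three compounds in this assay: a 4.9-fold higher number from compound 3 to compound 4 (0.69 log units; beyond the scatter), alongside a 5.3-fold higher number from compound 1 to compound 4 (0.73 log units; beyond the scatter) and an 11-fold higher number from compound 2 to compound 4 (1.06 log units; beyond the scatter), the last being the only step in the set graded large. Counting hydrogen-bond acceptors therefore does not sort these aryl groups: compound 1 and compound 2 have lower numbers than compound 3, but compound 4 goes against that pattern, since its 4-methoxyphenyl group counts as a hydrogen-bond acceptor and it still has the highest number of the four. No measurement shown here accounts for this rise, so its origin remains unassigned.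

The compounds shown leave open whether a hydroxy group or an amine in place of the methoxy would stay near compound 4 or return towards the number of compound 2. They also leave open whether a longer chain such as ethoxy would raise the number further, and whether any of these aryl steps would keep their size in another cell line.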